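Aryl ring exchange on the shared core: phenyl to pyridin-2-yl

The compounds below may be only part of what the source reports. "The series", "measured", "known", "first", "only" and "open" are said of these compounds alone.

Compound 1 `Cc1ncc([N+](=O)[O-])n1CCSc1nnc(-c2ccccc2)o1` is the reference point. In a functional assay on SGC-7901 cells (Homo sapiens) for cytotoxicity, read by MTT assay, with a stated time of 48 h (on this read-out higher numbers stand for weaker inhibition and lower numbers for stronger inhibition), compound 1 gives 30100 nM, the lowest of the three numbers to hand, although all three lie within the scatter of one another. Compound 2 `Cc1ccccc1-c1nnc(SCCn2c([N+](=O)[O-])cnc2C)o1` gives 32300 nM and compound 3 `COc1ccccc1-c1nnc(SCCn2c([N+](=O)[O-])cnc2C)o1` gives 30500 nM. The measured steps, a 1.1-fold higher number from compound 1 to compound 2 (0.03 log units; within the scatter), a 1.0-fold higher number from compound 1 to compound 3 (0.01 log units; within the scatter) and a 1.1-fold lower number from compound 2 to compound 3 (0.02 log units; within the scatter), all concern substituents on the phenyl and none leaves the scatter. Compound 4 `Cc1ncc([N+](=O)[O-])n1CCSc1nnc(-c2ccccn2)o1` differs from compound 1 by pyridin-2-yl in place of phenyl on an aromatic carbon. Among the compounds with values here, no measured step exchanges a ring atom of this aryl group, so the expectation rests on the flat series alone and carries extra uncertainty. The expected step is a 1.0-fold lower number from compound 1 to compound 4 (0.00 log units; within the scatter), within the scatter. Compound 4 is estimated at 30000 nM in this assay, with a range of 12000 nM to 75000 nM.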

Compound 4, half-maximal inhibitory concentration: 30000 nM
Estimate against measurement, compound 4: no gap at the digits printed; the range from low to high includes it.
By their numbers in this assay, from the lowest: compounds 4, 1, 3 and 2 (each within the scatter of the next).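

In this assay, exchanging a ring carbon of the aryl group for nitrogen, which adds a hydrogen-bond acceptor, stays within the scatter: a 1.0-fold lower number from compound 1 to compound 4 (0.00 log units; within the scatter). The comparisons with the substituted aryl groups agree, with a 1.0-fold lower number from compound 3 to compound 4 (0.01 log units; within the scatter) and a 1.1-fold lower number from compound 2 to compound 4 (0.03 log units; within the scatter), so this position has now shown no step beyond the scatter for either a ring-atom exchange or a substituent change. No evidence is at hand on what lies behind this flat response. As far as these compounds go, whether an amine or a carboxylic acid on the aryl ring would shift the number remains open, as does the effect of a longer chain on the shared core.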